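A few compounds are considered here, and "the series" means these few. Any claim that something is new, unique, unknown or untested is made for them only; others in the source may bear on it.

Measured so far:
compound 1, `Nc1ccccc1NC(=O)/C=C/c1ccc(Cn2cnc3c(NC4CCCCC4)nc(Cl)nc32)cc1`, 24.9%
compound 2, `Nc1ccccc1NC(=O)c1ccc(COCNc2nc(Nc3ccc(-c4ccccc4)cc3)c3ncn(C4CCCC4)c3n2)cc1`, 41.6%
compound 3, `CC(C)n1cnc2c(NCc3ccc(C(=O)Nc4ccccc4N)cc3)nc(Cl)nc21`, 80.5%

In a functional assay on NCI-H460 cells (Homo sapiens) for antiproliferative activity, read by CCK-8 assay, with a stated time of 72 h, tested at 8 uM (on this read-out higher numbers stand for a stronger effect at the one concentration tested and lower numbers for a weaker effect), compound 1 gives the lowest of the three numbers. Compound 2 stands higher by a margin beyond the scatter, and compound 3 stands higher still, also beyond the scatter. The account now turns to compound 4, `Nc1ccccc1NC(=O)/C=C/c1ccc(Cn2cnc3c(Nc4cccc(OC(F)(F)F)c4)nc(Cl)nc32)cc1`, which has not been measured. It differs from compound 1 in one place: 3-(trifluoromethoxy)phenyl in place of cyclohexyl on a nitrogen on an aromatic ring. Among the measured compounds shown here, no step between two measured compounds isolates such a change, so the expectation rests on the position of compound 1 alone. A shift of modest size upward is expected, one that may well stay within the scatter: a number 7.1 percentage points higher from compound 1 to compound 4 (within the scatter). Compound 4 is therefore estimated at 32%, with a range from 12% to 58%.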

Compound 4, a percentage reported as inhibition, at one concentration (the size of the read-out at that concentration, not a potency): 66.7%
Compound 4: middle estimate off by 34.7 percentage points, on the low side; measured number outside the range, above it.
By their numbers in this assay, from the lowest: compound 1; then compound 2; then compound 4; then compound 3.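

In this assay, 3-(trifluoromethoxy)phenyl in place of cyclohexyl on a nitrogen on an aromatic ring gives a number 41.8 percentage points higher from compound 1 to compound 4 (beyond the scatter), which shows that the read-out responds strongly to the group at this position on the core of compound 1. Nothing available explains this step. The compounds shown leave open whether an unsubstituted phenyl or a 3-methoxyphenyl on this nitrogen would give a similar step, so the contributions of the aromatic ring and the trifluoromethoxy group cannot be separated.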